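Pyrimidine-linked trimethoxyphenyl series: boronic acid at the para site

The compounds below may be only part of what the source reports. "The series", "measured", "known", "first", "only" and "open" are said of these compounds alone.

Measured so far:
compound 1 `COc1ccc(-c2cncnc2-c2cc(OC)c(OC)c(OC)c2)cc1` — 1140 nM
compound 2 `COc1cc(-c2ncncc2-c2ccc(SC)cc2)cc(OC)c1OC` — 220 nM
compound 3 `CCOc1ccc(-c2cncnc2-c2cc(OC)c(OC)c(OC)c2)cc1` — 250 nM

Compound 1 carries a methoxy on the second aryl ring and gives the highest number of the three in a functional assay on HeLa cells (Homo sapiens) for antiproliferative activity, read by CCK-8 assay, with a stated time of 72 h; on this read-out lower numbers stand for stronger inhibition and higher numbers for weaker inhibition. Its nearest neighbour is compound 3, which in this assay gives 250 nM; the furthest is compound 2, which gives 220 nM.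

Compound 4 `COc1cc(-c2ncncc2-c2ccc(B(O)O)cc2)cc(OC)c1OC` differs from compound 1 as follows: a group of 3 heavy atoms (1 boron, 2 oxygen; no ring) in place of a group of 2 heavy atoms (1 carbon, 1 oxygen; no ring), on an aromatic carbon.

Two measured steps start from the same position on compound 1. a 5.2-fold lower number from compound 1 to compound 2 (0.71 log units; beyond the scatter). a 4.6-fold lower number from compound 1 to compound 3 (0.66 log units; beyond the scatter). Both replacements at this site lowered the number by a modest amount, and the two products sit within the scatter of each other (a 1.1-fold higher number from compound 2 to compound 3 (0.06 log units; within the scatter)). Among the compounds with values here, neither step, however, introduces anything like the boron-bearing group with its two hydrogen-bond donors, so they set no direct precedent for compound 4. The data do not show how a change of this kind at this site is received, and the expected step from compound 1 to compound 4 is therefore set near no change, with a wide range that leans toward a higher number.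

For compound 4 the expected value in this assay is 2000 nM, with a range from 500 nM to 8000 nM, which corresponds to an expected step of a 1.8-fold higher number from compound 1 to compound 4 (0.24 log units; within the scatter).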

Compound 4, half-maximal inhibitory concentration: 4000 nM
The estimate for compound 4 lay 2.0-fold (0.30 log units) below the measured number, within the range that was stated.
By their numbers in this assay, from the lowest: compounds 2 and 3 (each within the scatter of the next); then compound 1; then compound 4.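

In this assay, the boron-bearing group is the only replacement shown on this aromatic carbon, para to a large group, that raises the number relative to methoxy (a 3.5-fold higher number from compound 1 to compound 4 (0.55 log units; beyond the scatter)), whereas the replacements in compounds 2 and 3 both lower it. The contrast with those two compounds is larger (a 16-fold higher number from compound 3 to compound 4 (1.20 log units; beyond the scatter); an 18-fold higher number from compound 2 to compound 4 (1.26 log units; beyond the scatter)), so this position is clearly sensitive to the group it carries, with the outcome depending on which group enters. Nothing measured here bears on why the boron-bearing group, with its 2 hydrogen-bond donors, is received in this way.

From the compounds shown here alone, it remains open whether the higher number belongs to the boron-bearing group itself or would also appear with other donor-bearing groups at this carbon, such as a hydroxyl, an amine or a carboxylic acid. Also open, going by these compounds, is whether a longer chain such as propoxy would keep the number near those of compounds 2 and 3 or take it back up toward that of compound 1.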